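Trifluoromethoxy in place of fluoro on compound 3

The source may report more compounds than this note shows. Statements on the series, on what has been measured and on what is new or still open speak of the compounds shown alone.

For the measured compounds named here, in a functional assay on SK-OV-3 cells (Homo sapiens) for antiproliferative activity, read by MTT assay, with a stated time of 72 h (on this read-out higher numbers stand for weaker inhibition and lower numbers for stronger inhibition), compound 3 `O=C(CCc1cccc2c1B(O)OC2)Nc1cccc(-c2ccc(F)cc2)c1` gives 93 nM, the lowest number of the three measured so far. Compound 1 `CC(C)c1cccc(NC(=O)CCc2cccc3c2B(O)OC3)c1` gives 510 nM and compound 2 `C#Cc1cccc(NC(=O)CCc2cccc3c2B(O)OC3)c1` gives 980 nM. These two do not separate: a 1.9-fold higher number from compound 1 to compound 2 (0.28 log units; within the scatter).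

Two measured steps lead to the 4-fluorophenyl group, a modest one, a 5.5-fold lower number from compound 1 to compound 3 (0.74 log units; beyond the scatter), and a large one, an 11-fold lower number from compound 2 to compound 3 (1.02 log units; beyond the scatter).

Compound 4 `O=C(CCc1cccc2c1B(O)OC2)Nc1cccc(-c2ccc(OC(F)(F)F)cc2)c1` carries trifluoromethoxy in place of fluoro on an aromatic carbon, para to a large group (trifluoromethoxy in place of fluoro on an aromatic carbon). Neither of those steps varies the fluoro itself, so they bear on this change only indirectly. They show that the number moves when the group on this side of the molecule is replaced, but the data hold no measured change at the fluoro position.

The expected change is a 1.1-fold higher number from compound 3 to compound 4 (0.03 log units; within the scatter), so no step beyond the scatter is anticipated. For compound 4 the estimate is 100 nM, with an expected range of 40 nM to 260 nM.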

Compound 4, half-maximal inhibitory concentration: 560 nM
Compound 4: middle estimate off by 5.6-fold (0.75 log units), on the low side, outside the stated range (above it).
By their numbers in this assay, from the lowest: compound 3; then compounds 1, 4 and 2 (each within the scatter of the next).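

In this assay, for the compounds shown here, the step of a 6.0-fold higher number from compound 3 to compound 4 (0.78 log units; beyond the scatter) is the first measured change at the fluoro position, and it shows that this position is not indifferent to its substituent. Going by these compounds alone, the low number of compound 3 therefore depends on the fluoro as well as on the 4-fluorophenyl group that replaced isopropyl and ethynyl in the earlier steps: with trifluoromethoxy on the same aromatic carbon, para to a large group, most of that advantage is gone. The change takes five heavy atoms in place of one, but this single pair cannot separate size from any other difference between the two groups.

From the compounds shown here alone, whether chloro, methyl, methoxy or an amine on this carbon would stay close to compound 3 remains open. Nothing measured here gives a reason for the step.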